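Cytotoxicity notes: fluoro for trifluoromethoxy in compound 4

The compounds below may be only part of what the source reports. "The series", "measured", "known", "first", "only" and "open" are said of these compounds alone.

Compound 3 `CN(CC1(C)CCn2cc([N+](=O)[O-])nc2O1)c1ccc(OC(F)(F)F)cc1` is known in an ADME assay on MRC5 cells (Homo sapiens) for cytotoxicity, read by resazurin assay, with a stated time of 72 h (a higher number here means a weaker inhibitor, a lower number a stronger inhibitor), only as a limit. In this assay compound 3 gives >= 40000 nM, a limit of the assay rather than a number. Compound 1 `CC1(CNc2ccc(F)cc2)CCn2cc([N+](=O)[O-])nc2O1` gives >= 40000 nM, also a limit. Compound 2 `CN(CC1CCn2cc([N+](=O)[O-])nc2O1)c1ccc(OC(F)(F)F)cc1` gives >= 40000 nM, again a limit. For the measured compounds named here, the single step between measured compounds, a step that the two limits leave unreadable from compound 2 to compound 3, therefore cannot be sized; every value shown sits at the limit of >= 40000 nM in this assay, at which 3 of the 3 values shown sit. Compound 4 `CN(CC1(C)CCn2cc([N+](=O)[O-])nc2O1)c1ccc(F)cc1` differs from compound 3 by fluoro in place of trifluoromethoxy on an aromatic carbon. Going by the values given here, no measured step bears on this change, and nothing among the values shown points to a reading inside the measurable range, so no step beyond the scatter is expected. The step from compound 3 to compound 4 is expected as a number no higher from compound 3 to compound 4 (the limit leaves the size open). Compound 4 is estimated at 40000 nM, within 20000 nM to 80000 nM, most likely reported once more as a limit.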

Compound 4, half-maximal inhibitory concentration: >= 40000 nM
Compound 4 was reported as a limit; the forecaster's own chance of this, stated with the estimate: 85%; the middle value sits exactly at the limit.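

The steps from compound 3 and from compound 1 to compound 4 cannot be read, since all three compounds are limits in this assay: the limit of >= 40000 nM in this assay, at which 4 of the 4 values shown sit.

The compounds shown leave open how far any of these changes would shift cytotoxicity within the measurable range.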